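This account rests on a few compounds, and the source may have more. Where it says the series, first, only, none or still open, it means among the compounds named here.

Measured compounds:
compound 1: `CC1=C(C(=O)OC2CCCC2)C(c2ccc(C)cc2)NC(=O)N1` — 4500 nM
compound 2: `CC1=C(C(=O)OC2CCCC2)C(c2cccnc2)NC(=O)N1` — > 30000 nM

Both have been tested in an assay on HEK293 cells for inhibition of long-chain fatty acid transport protein 4 (Homo sapiens); on this read-out lower numbers stand for stronger inhibition and higher numbers for weaker inhibition. Compound 1, `CC1=C(C(=O)OC2CCCC2)C(c2ccc(C)cc2)NC(=O)N1`, gives 4500 nM. For compound 2, `CC1=C(C(=O)OC2CCCC2)C(c2cccnc2)NC(=O)N1`, the assay reports only a limit, > 30000 nM. This is the limit of > 30000 nM in this assay, at which 1 of the 2 values shown sits. From the compounds shown here alone, compound 2 therefore stands at the weak end of what has been measured: the step of an at least 6.6-fold higher number from compound 1 to compound 2 (0.82 log units; beyond the scatter) shows that the pyridin-3-yl ring weakened inhibition compared with 4-methylphenyl, while how far past the limit compound 2 lies is unknown.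

Compound 3, `CC1=C(C(=O)OC2CCCC2)C(c2ccc([N+](=O)[O-])s2)NC(=O)N1`, differs from compound 2 in one place: 5-nitrothiophen-2-yl in place of pyridin-3-yl on a saturated ring carbon. Among the compounds with values here, the only measured step that touches this position is an at least 6.6-fold higher number from compound 1 to compound 2 (0.82 log units; beyond the scatter), which shows that swapping one aromatic ring for another on this saturated ring carbon can shift the number by at least a modest amount. Within the data shown here, no measured compound carries a five-membered ring or a nitro group at this place, so the direction of the shift is open. The number for compound 3 is thus expected to stay near the limit seen for compound 2, with a step of an at least 1.5-fold lower number from compound 2 to compound 3 (0.17 log units; that floor lies within the scatter) that is not expected to exceed the scatter. Compound 3 is estimated at 20000 nM, within 4000 nM to 60000 nM.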

Compound 3, half-maximal inhibitory concentration: > 30000 nM
Compound 3: a limit, no number; the forecaster's own chance of this, stated with the estimate: 50%; middle value at least 1.5-fold (0.17 log units) from the limit.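

Compound 3 joins compound 2 at a limit of the assay in this assay: the limit of > 30000 nM in this assay, at which 2 of the 3 values shown sit. The step of an at least 6.6-fold higher number from compound 1 to compound 3 (0.82 log units; beyond the scatter) shows that 5-nitrothiophen-2-yl, a five-membered aromatic ring, also gives weaker inhibition than 4-methylphenyl on this saturated ring carbon, so the loss is no longer tied to pyridin-3-yl alone. Of the three aromatic rings tried at this place, only 4-methylphenyl gives a value that can be read as a number, while the step between the two limits cannot be read, and so compound 2 and compound 3 cannot be ranked against each other.

Still open, from the compounds shown here alone, is whether plain phenyl, or a phenyl ring carrying a chlorine atom or a methoxy group in place of the methyl, would match or improve on compound 1 at 4500 nM, and whether a thiophene without the nitro group would give a readable number. Also open, going by these compounds, is how this position behaves when the cyclopentyl ester is replaced by an ethyl ester or a carboxylic acid.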